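This account rests on a few compounds, and the source may have more. Where it says the series, first, only, none or still open, it means among the compounds named here.

Three amides on a shared core have been measured: compound 1 `CCCCC(=O)Nc1nnc(-c2ccc([N+](=O)[O-])cc2)s1`, compound 2 `CCCC(=O)Nc1nnc(-c2ccc([N+](=O)[O-])cc2)s1` and compound 3 `O=C(Nc1nnc(-c2ccc([N+](=O)[O-])cc2)s1)c1ccc([N+](=O)[O-])cc1`. In an ADME assay on Vero cells (Chlorocebus sabaeus) for cytotoxicity, read by MTT assay, with a stated time of 72 h (a higher number here means a weaker inhibitor, a lower number a stronger inhibitor), compound 1 gives 278000 nM, compound 2 gives 301000 nM and compound 3 gives 290000 nM. Compound 3 thus stands second highest of the three numbers, with compound 2 nearest and compound 1 furthest, both gaps lying within the scatter, so no order among the three can be claimed. Compound 4 `COc1ccc(C(=O)Nc2nnc(-c3ccc([N+](=O)[O-])cc3)s2)cc1` differs from compound 3 by methoxy in place of nitro on an aromatic carbon. Within the data shown here, the only measured step is a 1.1-fold higher number from compound 1 to compound 2 (0.03 log units; within the scatter), which also altered the amide substituent, while the amide-bearing core was left alone; it gave no movement beyond the scatter, and the aromatic amide of compound 3 sits with the two alkyl amides as well. On that basis no step beyond the scatter is expected in this assay. The expected step is no change at the digits printed from compound 3 to compound 4 (within the scatter). Compound 4 is therefore estimated at 290000 nM, with a range from 150000 nM to 560000 nM.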

Compound 4, half-maximal inhibitory concentration: 278000 nM
For compound 4 the middle estimate is 1.0-fold (0.02 log units) above the measured one, and the stated range covers the measured number.
By their numbers in this assay, from the lowest: compounds 1, 4, 3 and 2 (each within the scatter of the next).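

In this assay, among these compounds, the exchange of methoxy for nitro on an aromatic carbon, para to a large group, gives a 1.0-fold lower number from compound 3 to compound 4 (0.02 log units; within the scatter) and is the first change at this position, where it produces no movement beyond the scatter. The 4-methoxyphenyl amide also stays level with the alkyl amides, with a 1.1-fold lower number from compound 2 to compound 4 (0.03 log units; within the scatter) for the exchange with propyl and no change at the digits printed from compound 1 to compound 4 (within the scatter) for the exchange with butyl, both within the scatter. No evidence is available that bears on this result.

As far as these compounds go, whether an amine or a carboxylic acid at this same aromatic carbon would also leave the number in place remains open. So does the effect of a much longer chain on the carbonyl carbon, or of replacing the nitro group that all four compounds share on the core.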